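A bromo analogue in the cytotoxicity series

The source may report more compounds than this note shows. Statements on the series, on what has been measured and on what is new or still open speak of the compounds shown alone.

Of the compounds shown here, three sharing one core have been measured in a functional assay on DLD-1 cells (Homo sapiens) for cytotoxicity, with a stated time of 48 h; on this read-out higher numbers stand for weaker inhibition and lower numbers for stronger inhibition. Compound 1 `CCOc1ccc2oc(/C=C/[S+](C)[O-])cc(=O)c2c1` gives 4900 nM. Compound 2 `CC(C)C(=O)Oc1ccc2oc(/C=C/[S+](C)[O-])cc(=O)c2c1` gives 9100 nM. Compound 3 `CCCCOc1ccc2oc(/C=C/[S+](C)[O-])cc(=O)c2c1` gives 4800 nM. Compound 2 holds the highest of the three numbers, yet the steps of a 1.9-fold higher number from compound 1 to compound 2 (0.27 log units; within the scatter) and a 1.9-fold lower number from compound 2 to compound 3 (0.28 log units; within the scatter) both stay within the scatter, so the three compounds cannot be told apart. The step of a 1.0-fold lower number from compound 1 to compound 3 (0.01 log units; within the scatter) likewise shows no movement.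

Compound 4 `C[S+]([O-])/C=C/c1cc(=O)c2cc(Br)ccc2o1` differs from compound 2 by bromo in place of (isopropylcarbonyl)oxy on an aromatic carbon. Going by the values given here, none of the measured steps exchanges the group at that aromatic carbon for anything other than another group on the same oxygen, so they bear on the new change only indirectly: each of them, a 1.9-fold higher number from compound 1 to compound 2 (0.27 log units; within the scatter), a 1.9-fold lower number from compound 2 to compound 3 (0.28 log units; within the scatter) and a 1.0-fold lower number from compound 1 to compound 3 (0.01 log units; within the scatter), stayed within the scatter when the group on that oxygen was varied. On that basis no step beyond the scatter is expected in this assay in either direction, though the exchange of an oxygen-linked group for bromo goes further than anything measured, and the range is set wide to allow for that. Compound 4 is therefore estimated at 6000 nM, with a range from 2000 nM to 18000 nM, which means an expected step of a 1.5-fold lower number from compound 2 to compound 4 (0.18 log units; within the scatter).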

Compound 4, half-maximal inhibitory concentration: 4500 nM
Compound 4: the middle estimate sits 1.3-fold (0.12 log units) above what was measured; low and high end bracket the measured number.
By their numbers in this assay, from the lowest: compounds 4, 3, 1 and 2 (each within the scatter of the next, the first and the last beyond it).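

In this assay, the oxygen link at this aromatic carbon proves dispensable, as a single bromine atom can take the place of either ether chain: a 1.1-fold lower number from compound 3 to compound 4 (0.03 log units; within the scatter) and a 1.1-fold lower number from compound 1 to compound 4 (0.04 log units; within the scatter) both leave compound 4 indistinguishable from the ethoxy and butoxy compounds. Going by these compounds alone, the earlier steps had varied only the group on that oxygen, and none of them passed the scatter, whereas a 2.0-fold lower number from compound 2 to compound 4 (0.31 log units; beyond the scatter) is the first step to do so, though it remains modest and compound 2 stays within the scatter of both compound 1 and compound 3. No measured evidence is available to account for the modest separation of compound 2 from compound 4.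

The compounds shown leave open whether the tolerance at this aromatic carbon extends beyond bromo and the oxygen-linked groups, for instance to an amine, a carboxylic acid or a plain hydrogen. They also leave open whether another halogen such as chloro or iodo would fall in the same narrow band, and whether a longer chain on the oxygen would stay there too.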